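This account rests on a few compounds, and the source may have more. Where it says the series, first, only, none or still open, it means among the compounds named here.

In an ADME assay (liver) for metabolic stability, with Liver microsome (Homo sapiens) as the target, using microsomes and NADPH, with a stated time of 1 h (on this read-out higher numbers stand for fast clearance and lower numbers for slow clearance), compound 1 `COc1nc(N2CCC(OC)CC2)nc(OC)c1NC(=O)CC(C)(C)C` gives 15.6 mL/min/kg. For the measured compounds named here, compound 2 `COc1nc(N2CCC(F)(F)CC2)nc(OC)c1NC(=O)CC(C)(C)C` gives 21.6 mL/min/kg, which stands within the scatter of the only other measured value. Compound 3 `COc1nc(N2CCCCC2)nc(OC)c1NC(=O)CC(C)(C)C` has piperidin-1-yl in place of 4,4-difluoropiperidin-1-yl on an aromatic carbon. Going by the values given here, the one measured step at this place, a 1.4-fold higher number from compound 1 to compound 2 (0.14 log units; within the scatter), is the only guide, and it gives no reason to expect a real shift in this assay. The estimated step, a 1.1-fold higher number from compound 2 to compound 3 (0.03 log units; within the scatter), is expected to stay within the scatter. Compound 3 is expected at 23 mL/min/kg, with an estimated range of 12 mL/min/kg to 43 mL/min/kg.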

Compound 3, clearance: 43.7 mL/min/kg
Beside the measured number, compound 3's estimate is 1.9-fold (0.28 log units) below it; the measured number lies above the stated range.
By their numbers in this assay, from the lowest: compounds 1 and 2 (each within the scatter of the next); then compound 3.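

In this assay the position proves responsive after all: a 2.0-fold higher number from compound 2 to compound 3 (0.31 log units; beyond the scatter) and a 2.8-fold higher number from compound 1 to compound 3 (0.45 log units; beyond the scatter). Compound 3, with the plain piperidin-1-yl, thus stands apart from both substituted rings, while compounds 1 and 2 stay within the scatter of each other, so a methoxy group or two fluorines on the saturated ring carbon go with similar, lower numbers. No measurement here accounts for this separation.

Open, going by these compounds, is whether a hydroxyl, a single fluorine or an amine on that saturated ring carbon would also give a lower number than compound 3. Also open, on these data alone, is whether a ring other than piperidine at this position would do the same.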